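The source may report more compounds than this note shows. Statements on the series, on what has been measured and on what is new or still open speak of the compounds shown alone.

Measured compounds in an assay for inhibition of arginase-1 (Bos taurus), with a stated time of 30 min, tested at 1 mM; a lower number here means less inhibition, a higher number more inhibition at the concentration tested (going by the name of the read-out):
compound 1 `COCCNC(=N)NCCCCC(=O)O` gives 35%
compound 2 `CCCCCNC(=N)NCCOC` gives 15%

Among the compounds with values here, compound 2 stands lowest of the two numbers; the nearest value is that of compound 1, and the step between them, a number 20 percentage points lower from compound 1 to compound 2 (beyond the scatter), is the only measured step in the set. That step concerns the carboxy end of the chain and does not bear on the change to compound 3 `COCCNC(=N)NCCC(C)C`, which is isopropyl in place of propyl on a saturated chain carbon, two bonds along the chain from an amine nitrogen. Within the data shown here, no measured step speaks to branching of this alkyl chain, so the expectation for the step is none beyond the scatter: no change at the digits printed from compound 2 to compound 3 (within the scatter). Compound 3 is therefore estimated at 15%, in the range 3% to 30%.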

Compound 3, a percentage reported as inhibition, at one concentration (the size of the read-out at that concentration, not a potency): 20%
Compound 3: middle estimate off by 5 percentage points, on the low side; the range from low to high includes it.
By their numbers in this assay, from the lowest: compounds 2 and 3 (each within the scatter of the next); then compound 1.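

Working notes: at this position in this assay, branching of the three-carbon chain gives a number 5 percentage points higher from compound 2 to compound 3 (within the scatter), so propyl and isopropyl are not told apart here. Isopropyl in place of 2-carboxyethyl gives a number 15 percentage points lower from compound 1 to compound 3 (beyond the scatter), a second step away from the carboxy-bearing compound 1 that lies beyond the scatter, now with the branched chain as the replacement. No supporting data bear on the reason for either step.

Open, on these data alone, is how a terminal amine on this chain would read, and whether a longer chain ending in a carboxylic acid would differ from compound 1.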